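This account rests on a few compounds, and the source may have more. Where it says the series, first, only, none or still open, it means among the compounds named here.

Measured so far:
Compound 1, `ClCc1ccc(Cn2cnc3c(Cl)ncnc32)cc1` — in a functional assay on HT-29 cells (Homo sapiens) for cytotoxicity, read by sulforhodamine B assay, with a stated time of 48 h (a lower number here means that less compound is tolerated, a higher number that more compound is tolerated), compound 1 gives "not determined" (no result reported).
Compound 2, `ClCc1ccc(Cn2cnc3nc(Cl)nc(Cl)c32)cc1` — in this assay compound 2 gives only a limit, > 100000 nM.

Compound 1 therefore stands without a single number in this assay. The one further result shown, that of compound 2, is a limit rather than a number: the limit of > 100000 nM in this assay, at which 1 of the 2 values shown sits, meaning the cells tolerated every concentration tested there.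

Compound 3, `ClCc1ccc(Cn2cnc3c(Cl)nc(Cl)nc32)cc1`, follows from compound 1 by chloro in place of hydrogen on an aromatic carbon, set between two ring nitrogen atoms of the shared core. Going by the values given here, no measured step exists for this change, so its size and direction cannot be read from the data. The only anchor is the limit of compound 2, another dichloro compound on the same core, which showed no measurable toxicity. For compound 3 the estimate is accordingly a weak or unmeasurable value, expected around 80000 nM, with a likely range from 20000 nM to 300000 nM.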

Compound 3, concentration lethal to 50% of the cells: > 100000 nM
Compound 3: only a limit was reported; the forecaster's own chance of this, stated with the estimate: 60%; at least 1.2-fold (0.09 log units) between middle value and limit.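

Going by these compounds alone, no step from compound 1 to compound 3 can be read, as compound 1 has no reported result and compound 3 gives only a limit. The compounds shown leave open whether chloro in place of hydrogen alters cell toxicity, and at what concentration any of them would become toxic.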